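Substituent swap on the aryl piperazine: compound 3 expected

This account rests on a few compounds, and the source may have more. Where it says the series, first, only, none or still open, it means among the compounds named here.

Measured compounds:
Compound 1, `CCCCCCCCn1cc(/C=C/C(=O)c2ccc(NC(=O)CN3CCN(c4ccccc4)CC3)cc2)nn1`: 52400 nM
Compound 2, `CCCCCCCCn1cc(/C=C/C(=O)c2ccc(NC(=O)CN3CCN(c4ccc([N+](=O)[O-])cc4)CC3)cc2)nn1`: 45400 nM

In a functional assay on A549 cells (Homo sapiens) for inhibition, read by MTT assay (a higher number here means a weaker inhibitor, a lower number a stronger inhibitor), compound 2 gives 45400 nM, the lower of the two numbers shown, while compound 1 gives 52400 nM. Among the measured compounds shown here, the one step connecting them, a 1.2-fold lower number from compound 1 to compound 2 (0.06 log units; within the scatter), lies within the scatter, so the two compounds cannot be told apart on these numbers.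

Compound 3, `CCCCCCCCn1cc(/C=C/C(=O)c2ccc(NC(=O)CN3CCN(c4ccccc4OC)CC3)cc2)nn1`, has not yet been measured. It differs from compound 2 in one place: 2-methoxyphenyl in place of 4-nitrophenyl on an amine nitrogen in a ring. For the measured compounds named here, the only measured step that bears on this change is the one from compound 1 to compound 2, which also altered the group on that same aromatic ring, and it produced no shift beyond the scatter. Going by the values given here, with a single within-scatter comparison as the sole guide, no step beyond the scatter is expected in this assay for compound 3 either, in neither direction. The estimate for compound 3 is therefore 48000 nM, with a range of 20000 nM to 115000 nM, which corresponds to an expected step of a 1.1-fold higher number from compound 2 to compound 3 (0.02 log units; within the scatter).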

Compound 3, half-maximal inhibitory concentration: 34000 nM
Beside the measured number, compound 3's estimate is 1.4-fold (0.15 log units) above it, and the stated range covers the measured number.
By their numbers in this assay, from the lowest: compounds 3, 2 and 1 (each within the scatter of the next).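

In this assay, exchanging the 4-nitrophenyl for 2-methoxyphenyl on the amine nitrogen of the six-membered ring gives a 1.3-fold lower number from compound 2 to compound 3 (0.13 log units; within the scatter) and the methoxy group that compound 3 carries where compound 1 has none gives a 1.5-fold lower number from compound 1 to compound 3 (0.19 log units; within the scatter) so neither change separates compound 3 from the compound it is compared with. Compound 2 had shown this for a single nitro group, whereas compound 3 extends it to a different group at a different place on the aromatic ring, and compounds 1, 2 and 3 now cannot be told apart here, with none going against that reading. Nothing measured alongside these numbers offers an explanation for them.

The compounds shown leave open whether a carboxylic acid or a primary amine on this aromatic ring, or a cyclohexyl group in place of the ring, would give a step beyond the scatter. They also leave open whether a shorter chain in place of the one on the shared core would move the number in this assay further than any of these aryl changes has.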